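Extending the glycine unit of compound 2 with a guanidine-bearing chain

This account rests on a few compounds, and the source may have more. Where it says the series, first, only, none or still open, it means among the compounds named here.

This account concerns a small set of purine-based amides and follows the step from compound 2 to compound 4. In a functional assay on the whole organism (Tail, strain ICR) with Mus musculus as the target, in the tail flick test, with a stated time of 90 min, at a dose of 25 umol/kg by the oral route (a higher number here means a stronger effect of the compound at the dose given, a lower number a weaker effect), compound 2, with the structure `O=C(CN(c1ncnc2c1ncn2C1CCCCO1)C1CC1)NCC(=O)OCc1ccccc1`, gives 25.9%. That is the lowest of the three numbers shown, but compound 1, with the structure `O=C(O)[C@@H]1CCCN1C(=O)CN(c1nc(Cl)nc2[nH]cnc12)C1CC1`, gives 26% in this assay, a number that lies within the scatter of compound 2, so the two cannot be placed in any order. Compound 3, with the structure `O=C(CN(c1nc(Cl)nc2[nH]cnc12)C1CC1)N[C@@H](CCC(=O)OCc1ccccc1)C(=O)OCc1ccccc1`, gives 50%, and that number stands beyond the scatter above compound 2.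

Compound 4, with the structure `N=C(N)NCCC[C@H](NC(=O)CN(c1ncnc2c1ncn2C1CCCCO1)C1CC1)C(=O)OCc1ccccc1`, has not yet been measured in this assay. The change from compound 2 to compound 4 is a group of 7 heavy atoms (4 carbon, 3 nitrogen; no ring) in place of a hydrogen atom, on a saturated chain carbon bound to an amide-type nitrogen and a carbonyl carbon. For the measured compounds named here, no single-point step between measured compounds is available here, so the size of the step cannot be read directly from the data. Going by the values given here, the only hint is that compound 3, which also carries a substituent on the saturated chain carbon bound to the amide-type nitrogen and the carbonyl carbon, gives 50%, a higher number than compound 2. On that basis the step is expected to be upward and of moderate size, a number 14.1 percentage points higher from compound 2 to compound 4 (beyond the scatter). Compound 4 is therefore estimated to give about 40% in this assay, within a range from 20% to 65%.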

Compound 4, a percentage reported as activity, at one dose (the size of the read-out at that dose, not a potency): 61.6%
Compound 4: the middle estimate sits 21.6 percentage points below what was measured; low and high end bracket the measured number.
By their numbers in this assay, from the lowest: compounds 2 and 1 (each within the scatter of the next); then compound 3; then compound 4.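

In this assay, the set now holds its first comparison that differs in one place, a number 35.7 percentage points higher from compound 2 to compound 4 (beyond the scatter), and this step lies beyond the scatter. It shows that, on the saturated chain carbon bound to an amide-type nitrogen and a carbonyl carbon, a group of 7 heavy atoms without a ring can take the place of a hydrogen atom, and the read-out rises rather than falls, with the rest of the structure unchanged. Nothing available explains this rise, so the step stands as an observation without a cause.

The compounds shown leave open whether the rise needs the whole guanidine-bearing chain or would also appear with a simple methyl group, or with an amine on a chain of the same or shorter length, at this carbon. They also leave open whether the opposite configuration at this carbon would give a similar step, and how the step would look on the chlorine-bearing core of the other compounds.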